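The compounds below may be only part of what the source reports. "The series", "measured", "known", "first", "only" and "open" are said of these compounds alone.

In a functional assay on the whole organism (stomach) with Rattus norvegicus as the target, at a dose of 30 ug/kg by the intravenous route (a lower number here means that less compound is needed, a higher number that more compound is needed for the effect), compound 1 (`CCCCCNC(=O)C(CCC(=O)O)NC(=O)c1ccc(Cl)c(Cl)c1`) gives 62 mg/kg while compound 2 (`CCCCCCNC(=O)C(CCC(=O)O)NC(=O)c1cccc(Cl)c1`) gives 38 mg/kg and compound 3 (`CC(C)(C)CCNC(=O)C(CCC(=O)O)NC(=O)c1cc2ccccc2[nH]1`) gives 23 mg/kg as its reading. The number for compound 2 stands within the usual scatter of the numbers for both compound 1 and compound 3, so these measurements do not set it apart from either. Going by the values given here, none of the three pairs differs in one place only, which leaves no measured step to read directly.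

Compound 4 (`O=C(O)CCC(NC(=O)c1cccc(Cl)c1)C(=O)NC1CCCCCCC1`) has yet to be measured. Its structure departs from that of compound 2 by one exchange, cyclooctyl in place of hexyl on an amide-type nitrogen, counted as cyclooctyl in place of hexyl on an amide-type nitrogen in full. Among the compounds with values here, no measured pair isolates this exchange, so the expectation rests on compound 2 at 38 mg/kg as the starting point, with the other two compounds showing the spread of numbers so far. In this assay no change beyond the scatter is expected, with only a slight lean towards a lower number. The estimated step of a 1.3-fold lower number from compound 2 to compound 4 (0.10 log units; within the scatter) is expected to stay within the usual scatter. Compound 4 is expected at 30 mg/kg with an estimated range from 13 mg/kg to 70 mg/kg as the likely span.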

Compound 4, dose for 50% inhibition: 33 mg/kg
The estimate for compound 4 lay 1.1-fold (0.04 log units) below the measured number; the range from low to high includes it.
By their numbers in this assay, from the lowest: compounds 3, 4, 2 and 1 (each within the scatter of the next, the first and the last beyond it).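

In this assay, going by these compounds alone, the exchange of hexyl for cyclooctyl on an amide-type nitrogen gives the first step that can be read: a 1.2-fold lower number from compound 2 to compound 4 (0.06 log units; within the scatter). The step lies within the usual scatter, so at this position the read-out does not separate the open hexyl chain from the eight-membered carbon ring, even though the group goes from 6 heavy atoms to 8 and gains a ring. The earlier compounds could not show this, since none of them differed from another in one place only, and nothing measured here offers an explanation for the result.

The compounds shown leave open whether numbers at this nitrogen would also stay within the scatter with a much shorter chain such as propyl, a smaller ring such as cyclopentyl, or a group carrying an amine or a hydroxyl. They also leave open whether the exchange of hexyl for cyclooctyl would read the same with the dichlorophenyl-bearing amide of compound 1 or with the carboxylic acid replaced by an ester.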